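This account rests on a few compounds, and the source may have more. Where it says the series, first, only, none or still open, it means among the compounds named here.

Compound 1, `CCCCCCCCCCCCO/N=C(\CCCCCC)c1cc(OC)c2c(c1OC)C(=O)C=CC2=O`, in a functional assay on A549 cells (Homo sapiens) for antiproliferative activity; on this read-out lower numbers stand for an effect already at smaller amounts and higher numbers for an effect only at larger amounts of compound: > 10 ug/mL
Compound 2, `CCCCCCCO/N=C/c1cc(OC)c2c(c1OC)C(=O)C=CC2=O`, in this assay: > 10 ug/mL

The value of compound 1 is a limit of the assay and not a number. The value of compound 2 is likewise only a limit. Going by the values given here, both results sit at the same place, (the limit of > 10 ug/mL in this assay, at which 2 of the 2 values shown sit), so neither gives a point from which a measured step could be read, and no step between the two is available.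

Compound 3, `CCCCCC/C(=N\OCCC)c1cc(OC)c2c(c1OC)C(=O)C=CC2=O`, has not yet been measured. It differs from compound 1 by hydrogen in place of nonyl on a saturated chain carbon, three bonds along the chain from an oxygen on an unsaturated carbon; seen one bond further out, this reads as dodecyl shortened to propyl on the oxime oxygen chain. With compound 1 at a limit, the expectation is that this shortening produces no step beyond the scatter, and compound 3 is expected to stay at the same limit, with an estimate of 15 ug/mL between 8 ug/mL and 40 ug/mL, the expected step being a step that the limit leaves unreadable from compound 1 to compound 3.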

Compound 3, concentration for half-maximal effect: > 10 ug/mL
Compound 3: only a limit was reported (the forecaster's own chance of this, stated with the estimate: 80%); the middle value is on the limit's open side.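

Compound 1 and compound 3 both end at a limit of the assay and not at a number, so no step between them can be read: the limit of > 10 ug/mL in this assay, at which 3 of the 3 values shown sit.

The compounds shown leave open whether the length of the oxime oxygen chain matters at all in this assay.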